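Compound 3: from 4-chlorobenzyl to 4-bromobenzyl

The source may report more compounds than this note shows. Statements on the series, on what has been measured and on what is new or still open speak of the compounds shown alone.

- Compound 1 `COc1cc(CN(C(=O)CSc2nc3ccccc3s2)c2cc(OC)c(OC)c(OC)c2)cc(OC)c1OC`: 45700 nM
- Compound 2 `COc1cc(N(Cc2ccc(Cl)cc2)C(=O)CSc2nc3ccccc3s2)cc(OC)c1OC`: > 80000 nM

In a functional assay on MGC-803 cells (Homo sapiens) for antiproliferative activity, read by MTT assay, with a stated time of 48 h (a higher number here means a weaker inhibitor, a lower number a stronger inhibitor), compound 2 stands at > 80000 nM, which is a limit of the assay and not a number. Compound 3 `COc1cc(N(Cc2ccc(Br)cc2)C(=O)CSc2nc3ccccc3s2)cc(OC)c1OC` has yet to be measured. It differs from compound 2 by bromo in place of chloro on an aromatic carbon. For the measured compounds named here, the only measured step that bears on this is an at least 1.7-fold higher number from compound 1 to compound 2 (0.24 log units; that floor lies within the scatter), which concerns a different replacement and gives no size for chloro to bromo. No step beyond the scatter is therefore expected in this assay. The expected step is a step that the limit leaves unreadable from compound 2 to compound 3. For compound 3 the estimated value is 85000 nM, with an expected range of 35000 nM to 200000 nM.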

Compound 3, half-maximal inhibitory concentration: 48100 nM
For compound 3 the middle estimate is 1.8-fold (0.25 log units) above the measured one; measured number inside the range.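

In this assay, bromo in place of chloro on an aromatic carbon para to a large group gives an at least 1.6-fold lower number from compound 2 to compound 3 (0.22 log units; that floor lies within the scatter). Compound 2 stands at a limit of the assay and not a number, so this step is only a floor: the limit of > 80000 nM in this assay, at which 1 of the 3 values shown sits. With the 4-bromobenzyl group, the change from the 3,4,5-trimethoxyphenyl group gives a 1.1-fold higher number from compound 1 to compound 3 (0.02 log units; within the scatter), so compound 3 retains a measured value without that group.

Going by these compounds, how far compound 3 truly lies from compound 2 remains unknown. Also open, on these data alone, is how an amine or a carboxylic acid at this aromatic carbon would compare with bromo.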